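The source may report more compounds than this note shows. Statements on the series, on what has been measured and on what is new or still open speak of the compounds shown alone.

Measured so far in a functional assay on NCI-H460 cells (Homo sapiens) for inhibition, read by MTT assay, with a stated time of 72 h; on this read-out lower numbers stand for stronger inhibition and higher numbers for weaker inhibition:
- Compound 1 `COc1cc(NC(C)CCCNC(=O)NNC(=O)Nc2cccc(F)c2)c2ncccc2c1`: 50000 nM
- Compound 2 `COc1cc(NC(C)CCCNC(=O)Nc2ccc(Cl)cc2)c2ncccc2c1`: 34000 nM
- Compound 3 `COc1cc(NC(C)CCCNC(=O)NNC(=O)Nc2cccc(Cl)c2)c2ncccc2c1`: 32000 nM

These three numbers lie close together. Compound 3 gives 32000 nM and cannot be ranked against the other two, since the steps that reach it are a 1.6-fold lower number from compound 1 to compound 3 (0.19 log units; within the scatter) and a 1.1-fold lower number from compound 2 to compound 3 (0.03 log units; within the scatter).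

The next compound, compound 4 `COc1cc(NC(C)CCCNC(=O)NNC(=O)Nc2ccc(O)cc2)c2ncccc2c1`, differs from compound 3 in one place: it has 4-hydroxyphenyl in place of 3-chlorophenyl on an amide-type nitrogen.

The closest evidence is the swap of chloro for fluoro on an aromatic carbon, which gave a 1.6-fold lower number from compound 1 to compound 3 (0.19 log units; within the scatter). A broader replacement gave a 1.5-fold lower number from compound 1 to compound 2 (0.17 log units; within the scatter), so it also produced no clear shift in this assay. None of the three measured compounds carries a 4-hydroxyphenyl group, so this evidence is indirect and the range must stay wide.

With no measured step beyond the scatter to build on, no step beyond the scatter is expected here, and the estimate amounts to a 1.3-fold higher number from compound 3 to compound 4 (0.10 log units; within the scatter). The expected value for compound 4 is 40000 nM, with an estimated range from 17000 nM to 90000 nM.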

Compound 4, half-maximal inhibitory concentration: > 100000 nM
Compound 4 gave a limit, no number; the forecaster's own chance of this, stated with the estimate: 15%; middle value at least 2.5-fold (0.39 log units) away from the limit.
By their numbers in this assay, from the lowest: compounds 3, 2 and 1 (each within the scatter of the next). At a limit, above all of these: compound 4.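

In this assay compound 4 stands at a limit of the assay and not at a number: the limit of > 100000 nM in this assay, at which 1 of the 4 values shown sits. Within the data shown here, every step among the earlier compounds stayed within the scatter, whereas placing 4-hydroxyphenyl on this amide-type nitrogen gives an at least 3.1-fold higher number from compound 3 to compound 4 (0.49 log units; beyond the scatter) and an at least 2.9-fold higher number from compound 2 to compound 4 (0.46 log units; beyond the scatter), the first evidence that the aryl group here can move the read-out beyond the scatter. The comparison with the 3-fluorophenyl group is less decisive, with an at least 2.0-fold higher number from compound 1 to compound 4 (0.30 log units; that floor lies within the scatter).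

As far as these compounds go, the change from 3-chlorophenyl to 4-hydroxyphenyl alters both the substituent and the ring position given in the group's name, so these compounds cannot separate the hydroxyl group itself from its placement, and the true size of each step stays unknown while compound 4 has only a limit. A 3-hydroxyphenyl group would test placement on this nitrogen, while a 4-methoxyphenyl or 4-chlorophenyl group in the same ((aryl)carbamoyl)amino setting would show whether the hydroxyl hydrogen goes with the higher number.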